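The source may hold more compounds than are shown below. What is called first, only, known or untested is meant among the compounds shown, and "the series" means these compounds.

Measured compounds in a functional assay on HEK293 cells for agonist activity at Toll-like receptor 8 (Homo sapiens), read by reporter gene assay; on this read-out lower numbers stand for an effect already at smaller amounts and higher numbers for an effect only at larger amounts of compound:
- compound 1 `CCCC(C)Nc1oc2c(C)ncc(CO)c2c1Nc1ccccn1` gives 9010 nM
- compound 2 `Cc1ncc(CO)c2c(Nc3ccccn3)c(NCc3ccccc3)oc12` gives 4910 nM

Compound 2 holds the lowest of the two numbers in this assay; its nearest neighbour is compound 1, and the step of a 1.8-fold lower number from compound 1 to compound 2 (0.26 log units; within the scatter) is within the scatter, so the two cannot be put in order.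

Compound 3 `Cc1ncc(CO)c2c(Nc3ccccn3)c(N[C@@H](C)c3ccccc3)oc12` is not yet measured. It differs from compound 2 by methyl in place of hydrogen on a saturated chain carbon bound to an aromatic carbon and a nitrogen on an aromatic ring.

Among the measured compounds shown here, no measured step covers this change. For the measured compounds named here, the only step available, a 1.8-fold lower number from compound 1 to compound 2 (0.26 log units; within the scatter), swaps the whole substituent on the ring nitrogen and stays within the scatter, which indicates that this position tolerates both a branched alkyl and a benzyl without a shift beyond the scatter. On that basis no step beyond the scatter is expected in this assay for adding a methyl at the chain carbon of the benzyl group; the expected step is a 1.1-fold lower number from compound 2 to compound 3 (0.04 log units; within the scatter).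

Compound 3 is therefore estimated at 4500 nM in this assay, with a range from 1500 nM to 13000 nM.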

Compound 3, half-maximal effective concentration: 4270 nM
Beside the measured number, compound 3's estimate is 1.1-fold (0.02 log units) above it; the range from low to high includes it.
By their numbers in this assay, from the lowest: compounds 3, 2 and 1 (each within the scatter of the next, the first and the last beyond it).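

In this assay, the methyl on the saturated chain carbon bound to an aromatic carbon and a nitrogen on an aromatic ring is the only change shown within the benzyl group, and it gives a 1.1-fold lower number from compound 2 to compound 3 (0.06 log units; within the scatter), so this carbon accepts one added carbon with no resolvable shift in the read-out. The wider swap of the whole substituent on this nitrogen now gives a 2.1-fold lower number from compound 1 to compound 3 (0.32 log units; beyond the scatter), a modest step and the only one in the series that clears the scatter, while the two steps that make it up each stay within it, so the 1-phenylethyl and benzyl groups cannot be separated here. No measurement on hand bears on the cause of either step.

Still open, as far as these compounds go, is whether the opposite configuration at this carbon, or a longer chain there such as ethyl in place of the methyl, would give a step beyond the scatter from compound 3. Also open, from the compounds shown here alone, is how a fluorine or methoxy group on the phenyl ring, or an amine or carboxylic acid on the chain, would read in this assay.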